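Swapping Chloro for Trifluoromethyl in Three Growth Inhibitors

The compounds below may be only part of what the source reports. "The series", "measured", "known", "first", "only" and "open" are said of these compounds alone.

Of the compounds shown here, three have been tested in a functional assay on MCF7 cells (Homo sapiens) for antiproliferative activity, read by sulforhodamine B assay, with a stated time of 48 h; on this read-out lower numbers stand for stronger inhibition of growth and higher numbers for weaker inhibition of growth. Compound 1 `O=C1C(=O)N(CCCNc2ccnc3cc(Cl)ccc23)c2ccccc21` gives 23500 nM. Compound 2 `FC(F)(F)c1ccc2c(NCCCN3CCN(c4ccnc5cc(Cl)ccc45)CC3)ccnc2c1` gives 4600 nM, and compound 3 `FC(F)(F)c1ccc2c(NCCCN3CCN(c4ccnc5cc(C(F)(F)F)ccc45)CC3)ccnc2c1` gives 17200 nM. The difference between the core of compound 1 and the core of compound 2 is not broken down here. Compound 2 and compound 3 differ in one place: trifluoromethyl in place of chloro on an aromatic carbon In this assay that change produced a 3.7-fold higher number from compound 2 to compound 3 (0.57 log units; beyond the scatter).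

Compound 4 `O=C1C(=O)N(CCCNc2ccnc3cc(C(F)(F)F)ccc23)c2ccccc21` has not yet been measured. It relates to compound 1 by the same change, trifluoromethyl in place of chloro on an aromatic carbon Both changes sit on an aromatic carbon in the same surroundings, so they count as the same change, occurring twice among these four compounds. Within the data shown here, compound 4 is expected to show a 3.0-fold higher number from compound 1 to compound 4 (0.47 log units; beyond the scatter), because the one measured instance gave a 3.7-fold higher number from compound 2 to compound 3 (0.57 log units; beyond the scatter). The expectation rests on that single step and on the value of compound 1 alone, so the range is kept wide. Compound 4 is estimated at 70000 nM, between 25000 nM and 200000 nM.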

Compound 4, concentration for 50% growth inhibition: 45300 nM
For compound 4 the middle estimate is 1.5-fold (0.19 log units) above the measured one; measured number inside the range.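

In this assay, putting trifluoromethyl in place of chloro on the core of compound 1 gives a 1.9-fold higher number from compound 1 to compound 4 (0.29 log units; within the scatter), so on this core the step alone cannot be told apart from repeat-measurement noise. Set beside the step on the other core, it shows no measurable disagreement: the same change on two cores in this assay, a 3.7-fold higher number (0.57 log units; beyond the scatter) from compound 2 to compound 3 and a 1.9-fold higher number (0.29 log units; within the scatter) from compound 1 to compound 4, 1.9-fold (0.29 log units) apart, within the scatter of two such steps The two steps are therefore compatible with the change carrying over from one core to the other, but they do not establish this, since only the step on the core of compound 2 stands clear of the scatter and two cores in a single assay cannot show how far the result extends through the series.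

The compounds shown leave open how a nitrile or a methoxy group would compare with chloro and trifluoromethyl on the same aromatic carbon. They also leave open whether the step would hold with a longer chain in these molecules.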